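Iodo added to compound 2: an expected step

The source may report more compounds than this note shows. Statements on the series, on what has been measured and on what is new or still open speak of the compounds shown alone.

Compound 1 `O=S(=O)(Nc1ccc(Cl)c(F)c1)c1ccc(-c2cnc(C3CC3)o2)cc1` gives > 100000 nM in a functional assay on cells (leukaemia cell line, Homo sapiens) for inhibition, read by sulforhodamine B assay, with a stated time of 48 h (on this read-out lower numbers stand for higher toxicity in this test and higher numbers for lower toxicity in this test), a limit of the assay.
Compound 2 `O=S(=O)(Nc1cccc(Cl)c1)c1ccc(-c2cnc(C3CC3)o2)cc1` gives > 100000 nM in this assay, a limit of the assay.
Compound 3 `Cc1cc(Cl)ccc1NS(=O)(=O)c1ccc(-c2cnc(C3CC3)o2)cc1` gives > 100000 nM in this assay, a limit of the assay.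

All three measured compounds share one core and differ only in the aryl group on the sulfonamide nitrogen, and every one of them sits at the limit of > 100000 nM in this assay, at which 3 of the 3 values shown sit. The steps among them, a step that the two limits leave unreadable from compound 1 to compound 2, a step that the two limits leave unreadable from compound 1 to compound 3 and a step that the two limits leave unreadable from compound 2 to compound 3, are therefore unreadable in size, and compound 2 stands at a limit alongside the other two, with no number to rank it.

Compound 4 `O=S(=O)(Nc1ccc(I)c(Cl)c1)c1ccc(-c2cnc(C3CC3)o2)cc1` is the compound yet to be measured. It differs from compound 2 by iodo in place of hydrogen on an aromatic carbon.

Among the compounds with values here, no measured step reports a readable size, so the evidence offers only that three different aryl groups on this nitrogen all leave the limit unpassed. On that basis compound 4 is expected to behave in the same way, with an expected step that the limit leaves unreadable from compound 2 to compound 4 from compound 2, that is none readable. The estimate for compound 4 in this assay is 120000 nM, within a range from 40000 nM to 400000 nM, and most probably the assay will again report only a limit.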

Compound 4, concentration lethal to 50% of the cells: > 100000 nM
Compound 4 gave a limit, no number; the forecaster's own chance of this, stated with the estimate: 80%; the middle value is on the limit's open side.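

Compound 4 gives only a limit in this assay, so its steps from compound 1, compound 2 and compound 3 cannot be read, and all four compounds now stand together: the limit of > 100000 nM in this assay, at which 4 of the 4 values shown sit.

The compounds shown leave open how these aryl groups on the sulfonamide nitrogen rank against one another, and whether any compound with the shared core gives a readable number in this assay at all.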